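Amide variation on the sulfonylpiperidine series

The source may hold more compounds than are shown below. What is called first, only, known or untested is meant among the compounds shown, and "the series" means these compounds.

Measured compounds:
compound 1 `O=C([C@@H]1CCCN(S(=O)(=O)c2ccc(S(=O)(=O)N3CC[C@@H](O)C3)cc2)C1)N1CCC(F)(F)CC1`, 210 nM
compound 2 `CC(C)S(=O)(=O)c1ccc(S(=O)(=O)N2CCC[C@@H](C(=O)N3CCC(F)(F)CC3)C2)cc1`, 11 nM
compound 3 `CCN(CC)S(=O)(=O)c1ccc(S(=O)(=O)N2CCC[C@@H](C(=O)N[C@H]3CCOC3)C2)cc1`, 1670 nM

In a functional assay on MIA PaCa-2 cells (Homo sapiens) for inhibition, read by MTT assay, with a stated time of 7 days (on this read-out lower numbers stand for stronger inhibition and higher numbers for weaker inhibition), compound 3 gives the highest number of the three; compound 1 sits nearest and compound 2 furthest, both beyond the scatter. Compound 4 `CCN(CC)S(=O)(=O)c1ccc(S(=O)(=O)N2CCC[C@@H](C(=O)N3CCS(=O)(=O)CC3)C2)cc1` differs from compound 3 by 1,1-dioxothiomorpholin-4-yl in place of (oxolan-3-yl)amino on a carbonyl carbon. Within the data shown here, no measured step touches this position: the one measured step, a 19-fold lower number from compound 1 to compound 2 (1.28 log units; beyond the scatter), changes the sulfonyl substituent only, and compound 3 also carries a different sulfonyl group from compounds 1 and 2, so the amide and sulfonyl effects cannot be separated. Compounds 1 and 2, both with a cyclic tertiary amide, give lower numbers than compound 3, which hints at a lower number for compound 4, though with wide uncertainty. Compound 4 is therefore expected at 500 nM, range 150 nM to 2000 nM, an estimated step of a 3.3-fold lower number from compound 3 to compound 4 (0.52 log units; beyond the scatter).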

Compound 4, half-maximal inhibitory concentration: 900 nM
The estimate for compound 4 lay 1.8-fold (0.26 log units) below the measured number; the measured number falls inside the stated range.
By their numbers in this assay, from the lowest: compound 2; then compound 1; then compounds 4 and 3 (each within the scatter of the next).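

In this assay, the first step read at this position, a 1.9-fold lower number from compound 3 to compound 4 (0.27 log units; within the scatter), replaces (oxolan-3-yl)amino with 1,1-dioxothiomorpholin-4-yl on the carbonyl carbon. This exchange of a five-membered ring for a six-membered ring, which also removes the hydrogen-bond donor and the defined stereocentre, leaves the number within the scatter. No measurement bearing on a cause is available.

The compounds shown do not separate the amide contribution from the sulfonyl contribution across the series. Also open, as far as these compounds go, is how an open-chain dimethylamino group or a morpholine ring would read on this carbonyl carbon.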